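The compounds below may be only part of what the source reports. "The series", "measured", "known", "first", "only" and "open" are said of these compounds alone.

Of the compounds shown here, three from this study have been tested in an ADME assay on HaCaT cells (Homo sapiens) for cytotoxicity, read by MTT assay, with a stated time of 72 h; a higher number here means a weaker inhibitor, a lower number a stronger inhibitor. Compound 2 `Cc1cc(S(=O)(=O)/N=C(\N)n2nccc2-c2ccccc2)c(SCc2ccccc2)cc1Cl` gives 18000 nM, the highest of the three numbers, although its gaps to both others lie within the scatter of repeated measurements. Compound 1 `Cc1cc(-c2ccccc2)n(/C(N)=N/S(=O)(=O)c2cc(C)c(Cl)cc2SCc2cccc3ccccc23)n1` gives 12000 nM, and compound 3 `Cc1cc(-c2ccccc2)n(/C(N)=N/S(=O)(=O)c2cc(C)c(Cl)cc2SCc2ccccc2)n1` gives 10000 nM.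

The unmeasured compound 4 `Cc1ccc(CSc2cc(Cl)c(C)cc2S(=O)(=O)/N=C(\N)n2nccc2-c2ccccc2)cc1` differs from compound 2 in one place: methyl in place of hydrogen on an aromatic carbon. For the measured compounds named here, two measured steps bear on this. The step of a 1.8-fold lower number from compound 2 to compound 3 (0.26 log units; within the scatter) is the same kind of change, methyl in place of hydrogen on an aromatic carbon, though on a different ring of the molecule. The step of a 1.2-fold lower number from compound 1 to compound 3 (0.08 log units; within the scatter) changes the group on the sulfur-bound chain carbon and also stays within the scatter. Every change seen so far on this shared core has left the number essentially where it was, so a small methyl added to the benzyl ring is expected to do the same.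

The expected step of a 1.2-fold lower number from compound 2 to compound 4 (0.08 log units; within the scatter) therefore lies within the scatter. Compound 4 is estimated at 15000 nM, with a range from 7000 nM to 32000 nM.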

Compound 4, half-maximal inhibitory concentration: 20000 nM
The estimate for compound 4 lay 1.3-fold (0.12 log units) below the measured number; the range from low to high includes it.
By their numbers in this assay, from the lowest: compounds 3, 1, 2 and 4 (each within the scatter of the next).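

In this assay, going from benzyl to 4-methylbenzyl gives a 1.1-fold higher number from compound 2 to compound 4 (0.05 log units; within the scatter), so a methyl on this six-membered aromatic ring, para to a large group, leaves the number where it was. The earlier methyl step, a 1.8-fold lower number from compound 2 to compound 3 (0.26 log units; within the scatter), sat on a different ring, so methyl has now been tested on two rings and neither step goes beyond the scatter. No measurement shown bears on this result.

From the compounds shown here alone, it remains open whether a group other than methyl at this same place, such as an amine, a carboxylic acid or a longer chain, would leave the number just as unmoved. The compounds shown also leave open whether any single change to the shared core can move the number beyond the scatter.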